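Methoxy for fluoro in a cytotoxicity series

A few compounds are considered here, and "the series" means these few. Any claim that something is new, unique, unknown or untested is made for them only; others in the source may bear on it.

Three compounds were measured in an ADME assay on MCF-10A cells (Homo sapiens) for cytotoxicity, read by MTT assay, with a stated time of 72 h; on this read-out lower numbers stand for stronger inhibition and higher numbers for weaker inhibition. Compound 1 `Cc1ccc(-c2ccc(F)cc2)n1-c1ccc(-c2nc3ccccc3s2)cc1` gives 40000 nM. In this assay compound 2 `COc1ccc(-c2ccc(C)n2-c2ccc(-c3nc4ccccc4s3)cc2)cc1` gives 36300 nM. In this assay compound 3 `Cc1ccc(-c2ccc(C)n2-c2ccc(-c3nc4ccc(F)cc4s3)cc2)cc1` gives 33600 nM. Going by the values given here, the single change methoxy in place of fluoro on an aromatic carbon produced a 1.1-fold lower number from compound 1 to compound 2 (0.04 log units; within the scatter). The difference between the core of compound 1 and the core of compound 3 is not broken down here. Compound 4 `COc1ccc2nc(-c3ccc(-n4c(C)ccc4-c4ccc(C)cc4)cc3)sc2c1` has not yet been measured; it differs from compound 3 by methoxy in place of fluoro on an aromatic carbon. Among the compounds with values here, this is the same kind of change as the one from compound 1 to compound 2, but not the same: there the place was on an aromatic carbon of a six-membered aromatic ring of carbon only, para to a large group, whereas here it is part of a fused or bridged system of two rings, meta to a fused ring and para to a fused ring. For compound 4 the expected step is a 1.1-fold lower number from compound 3 to compound 4 (0.02 log units; within the scatter). That expectation rests on the earlier change, which gave a 1.1-fold lower number from compound 1 to compound 2 (0.04 log units; within the scatter). Compound 4 is estimated at 32000 nM, expected between 18000 nM and 55000 nM.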

Compound 4, half-maximal inhibitory concentration: 34000 nM
Beside the measured number, compound 4's estimate is 1.1-fold (0.03 log units) below it, and the stated range covers the measured number.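

In this assay, methoxy in place of fluoro gave a 1.0-fold higher number from compound 3 to compound 4 (0.01 log units; within the scatter), so on this core too the swap left the number within the scatter. Set beside the earlier case, the change carries from one core to the other with no difference that can be told apart: the same change on two cores in this assay, a 1.1-fold lower number (0.04 log units; within the scatter) from compound 1 to compound 2 and a 1.0-fold higher number (0.01 log units; within the scatter) from compound 3 to compound 4, 1.1-fold (0.05 log units) apart, within the scatter of two such steps. Going by these compounds alone, this shows only that the swap did nothing readable in two settings, once on a ring outside the fused system and once on a carbon that is part of a fused or bridged system of two rings; since neither step has a size beyond the scatter, it does not show that a real effect of this change transfers between cores, nor that the same would hold on a third core.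

The compounds shown leave open whether an amine, a carboxylic acid or a longer chain at these places would move the number beyond the scatter. They also leave open whether any group at all on these cores would change the reading in this cell line.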